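The source may report more compounds than this note shows. Statements on the series, on what has been measured and on what is new or still open speak of the compounds shown alone.

Measured so far in a functional assay on MDA-MB-361 cells (Homo sapiens) for antiproliferative activity, read by MTT assay, with a stated time of 72 h; on this read-out higher numbers stand for weaker inhibition and lower numbers for stronger inhibition:
compound 1 `O=C1NN=C(c2ccccc2)/C1=C/Nc1cc(-c2ccccc2)[nH]n1`: 42700 nM
compound 2 `CCOC(=O)c1c[nH]nc1N/C=C1\C(=O)N(c2ccccc2)N=C1c1ccccc1`: 24700 nM
compound 3 `Cc1cc(N/C=C2\C(=O)N(c3ccccc3)N=C2c2ccccc2)n[nH]1`: 9980 nM

Compound 3 gives the lowest number of the three in this assay; compound 2 lies next to it, and compound 1 furthest away. Within the data shown here, the only one-place step in the set is a 2.5-fold lower number from compound 2 to compound 3 (0.39 log units; beyond the scatter), which changes a different part of the structure and does not touch the site altered here.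

Compound 4 `O=C1/C(=C\Nc2cc(-c3ccccc3)[nH]n2)C(c2ccccc2)=NN1c1ccccc1` is the next member. Against compound 3 the change is phenyl in place of methyl on an aromatic carbon. Among the measured compounds shown here, no measured step bears on this change. Compound 1 also carries a phenyl at that place but differs elsewhere and gives 42700 nM, so it offers no clean comparison.

Compound 4 is therefore expected near compound 3, at 15000 nM with a range of 5000 nM to 50000 nM. The estimated step of a 1.5-fold higher number from compound 3 to compound 4 (0.18 log units; within the scatter) should stay within the scatter or be small.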

Compound 4, half-maximal inhibitory concentration: 12200 nM
The estimate for compound 4 lay 1.2-fold (0.09 log units) above the measured number, and the stated range covers the measured number.
By their numbers in this assay, from the lowest: compounds 3 and 4 (each within the scatter of the next); then compounds 2 and 1 (each within the scatter of the next).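

In this assay phenyl in place of methyl on this aromatic carbon does not separate the two groups (a 1.2-fold higher number from compound 3 to compound 4 (0.09 log units; within the scatter)), so the larger ring adds no readable change at this place. With phenyl held on that carbon, phenyl in place of hydrogen on the amide-type nitrogen in a ring does register (a 3.5-fold lower number from compound 1 to compound 4 (0.54 log units; beyond the scatter)), so in this pair the nitrogen site moves the number while the carbon site does not. No measurement available here accounts for either step.

From the compounds shown here alone, whether an amine, a carboxylic acid or a longer chain on this aromatic carbon would stay level with methyl and phenyl remains open. Also open, going by these compounds, is whether the nitrogen step holds with methyl on the carbon.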